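Swapping the Hydroxyphenyl Arm of Compound 2

The source may report more compounds than this note shows. Statements on the series, on what has been measured and on what is new or still open speak of the compounds shown alone.

Compound 2 `O=C(/C=C/c1cccc(O)c1)c1cccc(-n2cc(-c3ccc(Cl)cc3)[nH]c2=O)c1` holds the second-highest of three numbers in a functional assay on HCT-15 cells (Homo sapiens) for inhibition (a lower number here means a stronger inhibitor of growth, a higher number a weaker inhibitor of growth), where compound 2 gives 2330 nM. Its nearest neighbour is compound 1 `O=C(/C=C/c1cccc(O)c1)c1cccc(-n2cc(-c3ccccc3)[nH]c2=O)c1`, which gives 3100 nM, and the step of a 1.3-fold lower number from compound 1 to compound 2 (0.12 log units; within the scatter). Compound 3 `COc1ccc(-c2cn(-c3cccc(C(=O)/C=C/c4cc(OC)c(OC)c(OC)c4)c3)c(=O)[nH]2)cc1` gives 1380 nM, which lies within the scatter of compound 2. Compound 4 `COc1cc(/C=C/C(=O)c2cccc(-n3cc(-c4ccc(Cl)cc4)[nH]c3=O)c2)ccc1O` differs from compound 2 by 4-hydroxy-3-methoxyphenyl in place of 3-hydroxyphenyl on a double-bonded chain carbon bound to a double-bonded chain carbon. Within the data shown here, no measured step changes this ring alone; compound 3 differs from compound 2 in more than one place, so it gives no clean guide. The expected step of a 1.2-fold lower number from compound 2 to compound 4 (0.07 log units; within the scatter) is therefore small, with no direction beyond the scatter. Compound 4 is accordingly estimated at 2000 nM, within a range of 800 nM to 5000 nM.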

Compound 4, concentration for 50% growth inhibition: 1800 nM
Compound 4: middle estimate off by 1.1-fold (0.05 log units), on the high side; the measured number falls inside the stated range.
By their numbers in this assay, from the lowest: compounds 3, 4, 2 and 1 (each within the scatter of the next, the first and the last beyond it).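

In this assay, the change from 3-hydroxyphenyl to 4-hydroxy-3-methoxyphenyl gives a 1.3-fold lower number from compound 2 to compound 4 (0.11 log units; within the scatter), so this arm can take the larger 4-hydroxy-3-methoxyphenyl group with no change beyond the scatter. Among these compounds, this is the first clean reading at this ring, as compound 3 differs from compound 2 in more than one place. No measurement here explains this result.

The effects of the methoxy group and the shifted hydroxy group remain unseparated. From the compounds shown here alone, how this arm would respond to an amine or a carboxylic acid also remains open.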